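The source may hold more compounds than are shown below. What is called first, only, known or untested is meant among the compounds shown, and "the series" means these compounds.

Two compounds of the shared core carry a methoxy group on the aromatic ring. In an assay on isolated protein for inhibition of alpha-galactosidase (Coffea arabica), tested at 1000 uM (a higher number here means more inhibition at the concentration tested (going by the name of the read-out), a lower number less inhibition), compound 1 `COc1ccc([C@]2(CO)NC[C@@H](O)[C@@H]2O)cc1` gives 7.5%. In this assay compound 2 `COc1cccc([C@]2(CO)NC[C@@H](O)[C@@H]2O)c1` gives 1.6%; the two numbers lie within the scatter of each other, so compound 2 stands with compound 1 at a low level of inhibition. Compound 3 `COc1ccc([C@]2(CO)NC[C@@H](O)[C@@H]2O)cc1OC` differs from compound 2 by methoxy in place of hydrogen on an aromatic carbon. Within the data shown here, no measured step of this kind is known; the expected change from compound 2 to compound 3 is a number 3.4 percentage points higher from compound 2 to compound 3 (within the scatter), none beyond the scatter. Compound 3 is expected to give 5%, between 0% and 15%.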

Compound 3, a percentage reported as inhibition, at one concentration (the size of the read-out at that concentration, not a potency): 0%
Compound 3: the middle estimate sits 5 percentage points above what was measured; the measured number falls inside the stated range.
By their numbers in this assay, from the lowest: compounds 3, 2 and 1 (each within the scatter of the next).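

In this assay, methoxy in place of hydrogen on an aromatic carbon, ortho to a methoxy group and para to a group of 9 heavy atoms, gives a number 1.6 percentage points lower from compound 2 to compound 3 (within the scatter) and leaves the series at a low level of inhibition. The same kind of change read from the other side gives a number 7.5 percentage points lower from compound 1 to compound 3 (within the scatter), so a second methoxy group on the ring shifts the read-out beyond the scatter in neither step. Nothing available explains these numbers. Still open, from the compounds shown here alone, is whether an amine, a carboxylic acid or a longer alkoxy chain at this position would raise inhibition above this level.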